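Moving the fluorine from the 3- to the 2-position of the benzamide

The compounds below may be only part of what the source reports. "The series", "measured", "known", "first", "only" and "open" are said of these compounds alone.

Two measured compounds share one core and differ only in the fluorophenyl on the carbonyl carbon. Compound 1 `CN1CCN(c2ccc(Nc3nc(-c4cccc(NC(=O)c5ccc(F)cc5)c4)sc3C(N)=O)cc2)CC1` carries a 4-fluorophenyl there, and in a functional assay on Ramos cells (Homo sapiens) for antiproliferative activity, read by CCK-8 assay, with a stated time of 72 h, tested at 40 uM (on this read-out lower numbers stand for less inhibition and higher numbers for more inhibition at the one concentration tested (going by the name of the read-out)), compound 1 gives 95.9%. Compound 2 `CN1CCN(c2ccc(Nc3nc(-c4cccc(NC(=O)c5cccc(F)c5)c4)sc3C(N)=O)cc2)CC1` carries a 3-fluorophenyl instead, and in this assay compound 2 gives 16.2%. Within the data shown here, the single step seen so far, a number 79.7 percentage points lower from compound 1 to compound 2 (beyond the scatter), is large, so compound 2 stands as the lower of the two numbers, well apart from compound 1.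

Compound 3 `CN1CCN(c2ccc(Nc3nc(-c4cccc(NC(=O)c5ccccc5F)c4)sc3C(N)=O)cc2)CC1` is reached from compound 2 by the difference (2-fluorophenyl in place of 3-fluorophenyl on a carbonyl carbon). Among the measured compounds shown here, only one measured step involves the fluorophenyl on the carbonyl carbon, and it concerns a different pair of positions, so it shows that where the fluorine sits can move the read-out strongly but not in which direction a 2-fluorophenyl will move it. The estimate for compound 3 therefore rests on little and is wide; it is expected to lie between the two measured numbers, as a step of a number 28.8 percentage points higher from compound 2 to compound 3 (beyond the scatter). Compound 3 is thus estimated at 45%, with a range from 8% to 90%.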

Compound 3, a percentage reported as inhibition, at one concentration (the size of the read-out at that concentration, not a potency): 95.5%
For compound 3 the middle estimate is 50.5 percentage points below the measured one, and the stated range ends below it.
By their numbers in this assay, from the lowest: compound 2; then compounds 3 and 1 (each within the scatter of the next).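

In this assay, the 2-fluorophenyl on the carbonyl carbon restores the high number lost with the 3-fluorophenyl, giving a number 79.3 percentage points higher from compound 2 to compound 3 (beyond the scatter). Among these three compounds, the low number therefore belongs to the 3-fluorophenyl alone, and shifting the fluorine away from the 4-fluorophenyl does not lower the read-out in itself. Against the 4-fluorophenyl, the 2-fluorophenyl gives a number 0.4 percentage points lower from compound 1 to compound 3 (within the scatter), so this read-out does not separate those two fluorine placings, and no measurement at hand offers an explanation for the outlying 3-fluorophenyl.

Both compound 1 and compound 3 are known here only from inhibition at a single concentration, so these numbers leave open whether the two differ in potency at lower concentrations. Going by these compounds, it also remains open whether the sharp dependence on placing is particular to fluorine or would recur with a chlorophenyl, a methoxyphenyl or an aminophenyl on the same carbonyl carbon, and where an unsubstituted phenyl would fall relative to compound 2 and compound 3.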